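Amide substituent change from compound 3 to compound 4

This account rests on a few compounds, and the source may have more. Where it says the series, first, only, none or still open, it means among the compounds named here.

In a functional assay on PC-3 cells (Homo sapiens) for antiproliferative activity, read by MTT assay, with a stated time of 24 h (a lower number here means a stronger inhibitor, a higher number a weaker inhibitor), compound 1 `CCn1c(C(=O)N[C@H](C)CO)ccc1C(CC)(CC)c1ccc(OCS(=O)(=O)c2ccccc2)c(C)c1` gives 7790 nM and compound 2 `CCn1c(C(=O)NC(C)(C)CO)ccc1C(CC)(CC)c1ccc(OCS(=O)(=O)c2ccccc2)c(C)c1` gives 9850 nM. The change between them is a 1.3-fold higher number from compound 1 to compound 2 (0.10 log units; within the scatter). Compound 3 `CCn1c(C(=O)NC2(CO)CC2)ccc1C(CC)(CC)c1ccc(OCS(=O)(=O)c2ccccc2)c(C)c1` gives 3560 nM, the lowest of the three numbers.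

Compound 4 `CCn1c(C(=O)N[C@H](CO)CCO)ccc1C(CC)(CC)c1ccc(OCS(=O)(=O)c2ccccc2)c(C)c1` carries 3-hydroxy-1-(hydroxymethyl)propyl in place of 1-(hydroxymethyl)cyclopropyl on an amide-type nitrogen. The entering group has no ring, so the closest evidence comes from the two measured steps into the cyclopropyl compound: a 2.2-fold lower number from compound 1 to compound 3 (0.34 log units; beyond the scatter) and a 2.8-fold lower number from compound 2 to compound 3 (0.44 log units; beyond the scatter). Both are modest, and removing the ring would reverse their direction. Within the data shown here, no measured compound carries the 3-hydroxy part of the entering group, which leaves that part of the change untested. A modest rise is therefore expected in this assay, with an estimated size of a 2.0-fold higher number from compound 3 to compound 4 (0.29 log units; within the scatter). For compound 4 the estimated value is 7000 nM, with an expected range of 2800 nM to 17000 nM.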

Compound 4, half-maximal inhibitory concentration: 12100 nM
Compound 4: the middle estimate sits 1.7-fold (0.24 log units) below what was measured; measured number inside the range.
By their numbers in this assay, from the lowest: compound 3; then compounds 1, 2 and 4 (each within the scatter of the next).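

In this assay, opening the ring and adding a second hydroxyl in one change gives a 3.4-fold higher number from compound 3 to compound 4 (0.53 log units; beyond the scatter), a step beyond the scatter that shows this amide-type nitrogen does not tolerate every replacement of 1-(hydroxymethyl)cyclopropyl equally. The comparisons among groups without a ring, a 1.2-fold higher number from compound 2 to compound 4 (0.09 log units; within the scatter) and a 1.6-fold higher number from compound 1 to compound 4 (0.19 log units; within the scatter), stay within the scatter, so among these four compounds only compound 3 stands apart, and the 3-hydroxy part of the entering group shows no separate effect. Nothing measured here explains the difference.

As far as these compounds go, whether the lower number of compound 3 belongs to the three-membered ring alone remains open, and a 1-(hydroxymethyl)cyclobutyl group on the same nitrogen would test this. Also open, from the compounds shown here alone, is what an amine or a carboxylic acid would do in place of the hydroxymethyl on the cyclopropyl ring.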